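Swapping the acyl group for methylsulfonyl on compound 1

The compounds below may be only part of what the source reports. "The series", "measured", "known", "first", "only" and "open" are said of these compounds alone.

Measured in a functional assay on ID8 cells (Mus musculus) for antiproliferative activity; on this read-out lower numbers stand for stronger inhibition and higher numbers for weaker inhibition:
- compound 1 `O=C(Nc1ccc(O)c2c(=O)cc(-c3ccccc3Cl)oc12)c1ccc(Cl)c(Cl)c1`: 13000 nM
- compound 2 `O=C(Nc1c(O)cc(O)c2c(=O)cc(-c3ccccc3Cl)oc12)c1ccccc1`: "not determined" (no result reported)
- compound 3 `C[C@H](NC(=O)OC(C)(C)C)C(=O)Nc1ccc(O)c2c(=O)cc(-c3ccccc3Cl)oc12`: 9800 nM

Within the data shown here, only two numbers are available in this assay, so the standing of compound 1 is easily told. Among the measured compounds shown here, it lies level with the single other measured compound: a 1.3-fold lower number from compound 1 to compound 3 (0.12 log units; within the scatter). Compound 2 offers no guidance, since it has no number.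

The next compound to be tested is compound 4 `CS(=O)(=O)Nc1ccc(O)c2c(=O)cc(-c3ccccc3Cl)oc12`, and its change from compound 1 is methylsulfonyl in place of (3,4-dichlorophenyl)carbonyl on a nitrogen on an aromatic ring. In words, methylsulfonyl takes the place of (3,4-dichlorophenyl)carbonyl on a nitrogen on an aromatic ring.

For the measured compounds named here, one measured step bears on this change. It exchanged 3,4-dichlorophenyl for 1-((tert-butoxycarbonyl)amino)ethyl on a carbonyl carbon, and that large exchange of groups left the number within the scatter: a 1.3-fold lower number from compound 1 to compound 3 (0.12 log units; within the scatter). Going by the values given here, that step kept the carbonyl, however, whereas compound 4 loses it, and no measured step shows what such a loss does. The expectation is therefore no step beyond the scatter, held with wide margins on either side. The expected step is a 1.1-fold lower number from compound 1 to compound 4 (0.03 log units; within the scatter). For compound 4 the estimated value is 12000 nM, with an expected range from 4000 nM to 40000 nM.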

Compound 4, half-maximal inhibitory concentration: 16000 nM
For compound 4 the middle estimate is 1.3-fold (0.12 log units) below the measured one; the range from low to high includes it.
By their numbers in this assay, from the lowest: compounds 3, 1 and 4 (each within the scatter of the next).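

In this assay, the step of a 1.2-fold higher number from compound 1 to compound 4 (0.09 log units; within the scatter) shows that the carbonyl on this nitrogen on an aromatic ring can be replaced, and the six-membered aromatic ring and the chlorine atoms of the (3,4-dichlorophenyl)carbonyl group removed, without the number leaving the scatter. The earlier exchange, a 1.3-fold lower number from compound 1 to compound 3 (0.12 log units; within the scatter), had kept the carbonyl, so it could not show this; the two changes now show that very different groups can stand on this nitrogen with no step beyond the scatter from compound 1. No accompanying measurement explains why the number holds when the group changes so much.

The compounds shown leave open whether any group on this nitrogen can move the number beyond the scatter in either direction, for instance a free amine with no acyl or sulfonyl group, a phenylsulfonyl group, or a carboxylic acid at the end of a longer chain. They also leave open what a second hydroxyl on the shared core does, as compound 2 has no reported number in this assay.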